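Swapping a Pentyl End for 4-Methylphenoxy

The source may hold more compounds than are shown below. What is called first, only, known or untested is meant among the compounds shown, and "the series" means these compounds.

Compound 1 `Cc1ccc(-c2cnc(N(Cc3ccc(C(=O)NO)cc3)CC(C)C)s2)cc1`: 7420 nM
Compound 2 `CCN(Cc1ccc(C(=O)NO)cc1)c1ncc(-c2ccc(C)cc2)s1`: 1120 nM
Compound 3 `CCCCCCCCN(Cc1ccc(C(=O)NO)cc1)c1ncc(-c2ccc(C)cc2)s1`: 8760 nM

In a functional assay on HepG2 cells (Homo sapiens) for antiproliferative activity, read by MTT assay, with a stated time of 48 h (a higher number here means a weaker inhibitor of growth, a lower number a stronger inhibitor of growth), compound 3 gives 8760 nM, within the scatter of compound 1, while compound 2 has the lowest number of the three. The next compound, compound 4 `Cc1ccc(OCCCN(Cc2ccc(C(=O)NO)cc2)c2ncc(-c3ccc(C)cc3)s2)cc1`, has not yet been measured. It differs from compound 3 as follows: 4-methylphenoxy in place of pentyl on a saturated chain carbon, three bonds along the chain from a nitrogen on an aromatic ring. This places 4-methylphenoxy in place of pentyl on a saturated chain carbon, three bonds along the chain from a nitrogen on an aromatic ring.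

Within the data shown here, three measured steps bear on this change, all at the same chain. Hexyl in place of hydrogen gave a 7.8-fold higher number from compound 2 to compound 3 (0.89 log units; beyond the scatter), and methyl in place of isopropyl gave a 6.6-fold lower number from compound 1 to compound 2 (0.82 log units; beyond the scatter), both modest. Heptyl in place of isopropyl gave a 1.2-fold higher number from compound 1 to compound 3 (0.07 log units; within the scatter), within the scatter. Among the measured compounds shown here, no measured compound carries a ring on this chain, so the data give little guidance on the new group. Only a small shift, with no clear direction, is therefore expected. The expected step is a 1.3-fold lower number from compound 3 to compound 4 (0.13 log units; within the scatter). Compound 4 is estimated at 6500 nM, with an expected range from 2500 nM to 17000 nM.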

Compound 4, concentration for 50% growth inhibition: 12200 nM
Beside the measured number, compound 4's estimate is 1.9-fold (0.27 log units) below it, and the stated range covers the measured number.
By their numbers in this assay, from the lowest: compound 2; then compounds 1, 3 and 4 (each within the scatter of the next).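

Replacing pentyl with 4-methylphenoxy puts the first ring on this chain, and in this assay the change stays within the scatter, with a 1.4-fold higher number from compound 3 to compound 4 (0.14 log units; within the scatter) as the step. The same holds against the isopropyl-bearing chain, where 2-(4-methylphenoxy)ethyl gives a 1.6-fold higher number from compound 1 to compound 4 (0.22 log units; within the scatter) as its step, whereas (4-methylphenoxy)methyl in place of hydrogen gives an 11-fold higher number from compound 2 to compound 4 (1.04 log units; beyond the scatter) as the largest step seen at this position. Compound 2 therefore remains apart from the other three, and a terminal aromatic ring linked through oxygen does not restore its number. No supporting data explain this result.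

Going by these compounds, whether an amine or a carboxylic acid at the end of this chain would lower the number remains open. So does the course of the number across plain propyl, butyl and pentyl chains, which would lie in length between the ethyl of compound 2 and the octyl of compound 3.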